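The source may report more compounds than this note shows. Statements on the series, on what has been measured and on what is new or still open speak of the compounds shown alone.

Three compounds have so far been measured in a physicochemical assay for lipophilicity, read by mass spectrometry; on this read-out higher numbers stand for higher lipophilicity and lower numbers for lower lipophilicity:

- compound 1 `CCOc1ccc(NC(=O)C2Cc3cc(OC)c(OC)cc3C2=O)cc1` gives 2.42
- compound 2 `COc1cc2c(cc1OC)C(=O)C(C(=O)Nc1ccc(F)cc1)C2` gives 2.36
- compound 3 `CCOc1ccccc1NC(=O)C1Cc2cc(OC)c(OC)cc2C1=O` gives 2.42

Compound 1 and compound 3 are built from the same atoms joined differently; the difference between the two cores is not broken down here, and their two values sit level with each other within the scatter. Compound 2 is obtained from compound 1 by fluoro in place of ethoxy on an aromatic carbon, and in this assay that change gave a number 0.06 log units lower from compound 1 to compound 2 (within the scatter).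

Compound 4 `COc1cc2c(cc1OC)C(=O)C(C(=O)Nc1ccccc1F)C2` has not yet been measured. It differs from compound 3 by fluoro in place of ethoxy on an aromatic carbon. Within the data shown here, this is the same kind of change as the one from compound 1 to compound 2, not the same: there the entering fluoro sits para to a large group, here it sits ortho to a large group.

Because a number 0.06 log units lower from compound 1 to compound 2 (within the scatter) was within the scatter, the step in this assay is expected to be a number 0.06 log units lower from compound 3 to compound 4 (within the scatter). Compound 4 is accordingly estimated at 2.36, with a likely range from 2.1 to 2.62.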

Compound 4, partition coefficient: 2.36
Compound 4: the middle estimate sits on the measured number at the digits printed; low and high end bracket the measured number.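

In this assay, fluoro in place of ethoxy, here ortho to a large group, gave a number 0.06 log units lower from compound 3 to compound 4 (within the scatter), which matches at the digits printed a number 0.06 log units lower from compound 1 to compound 2 (within the scatter), while 2-fluorophenyl in place of 4-fluorophenyl on the amide-type nitrogen gave no change at the digits printed from compound 2 to compound 4 (within the scatter). The swap therefore stayed within the scatter in both settings, but steps this small show only that no shift could be detected in either pair, not that a real shift of fixed size carries from one compound pair to another. No available measurement bears on why these values came out as they did.

The compounds shown leave open how an amine, a carboxylic acid or a longer chain would read on that aromatic carbon in place of ethoxy. They also leave open whether the agreement between the two steps would hold for any such group.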